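The source may report more compounds than this note shows. Statements on the series, on what has been measured and on what is new or still open speak of the compounds shown alone.

Measured compounds in an ADME assay on HepG2 2.2.15 cells (Homo sapiens) for cytotoxicity, read by MTT assay, with stated times of 48 h and 9 days; a higher number here means that more compound is tolerated, a lower number that less compound is tolerated:
- compound 1, `COc1cccc(NC(=O)/C=C/c2coc3cc(OC)ccc3c2=O)c1`, gives 1130000 nM
- compound 2, `O=C(/C=C/c1coc2cc(O)ccc2c1=O)Nc1ccccc1`, gives 821000 nM

Compound 1 has the higher of the two numbers in this assay, but its gap to compound 2 lies within the scatter, so the two values show no difference that can be read. Within the data shown here, no step between measured compounds is available for the change now considered.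

Compound 3, `COc1ccc2c(=O)c(/C=C/C(=O)Nc3ccc(C)cc3)coc2c1`, differs from compound 1 in one place: 4-methylphenyl in place of 3-methoxyphenyl on an amide-type nitrogen. Among the measured compounds shown here, with only two measured compounds, both tolerated to a similar degree, no step beyond the scatter is expected in either direction; the expected step is a 1.1-fold lower number from compound 1 to compound 3 (0.05 log units; within the scatter). Compound 3 is expected to give 1000000 nM, with a range from 400000 nM to 2500000 nM.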

Compound 3, half-maximal cytotoxic concentration: 979000 nM
Beside the measured number, compound 3's estimate is 1.0-fold (0.01 log units) above it, and the stated range covers the measured number.
By their numbers in this assay, from the lowest: compounds 2, 3 and 1 (each within the scatter of the next).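

In this assay, 4-methylphenyl in place of 3-methoxyphenyl on an amide-type nitrogen gives a 1.2-fold lower number from compound 1 to compound 3 (0.06 log units; within the scatter), the first single-place step available in the series. At this position, the exchange of these two aryl groups, with the loss of the hydrogen-bond acceptor counted in the leaving group, produces no readable difference in tolerated concentration. No measured evidence bears on the reason for this result. On these data alone, whether an amine or a carboxylic acid on the phenyl group would move the number remains open. A longer chain in place of the phenyl group also remains untested among the compounds shown.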